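This account rests on a few compounds, and the source may have more. Where it says the series, first, only, none or still open, it means among the compounds named here.

Compound 1 `CC1CCN(C2CCN(S(=O)(=O)c3cccc(C(F)(F)F)c3)CC2)CC1`: > 5000 nM
Compound 2 `COc1ccccc1-c1ccc(S(=O)(=O)N2CCC(N3CCC(C)CC3)CC2)cc1`: 26 nM
Compound 3 `CC1CCN(C2CCN(S(=O)(=O)c3ccc(Cl)c(C(F)(F)F)c3)CC2)CC1`: 17 nM

All three share one core and were compared in a functional assay on DLD-1 cells (Homo sapiens) for antiproliferative activity, read by CellTiter-Glo, with a stated time of 72 h; a lower number here means a stronger inhibitor, a higher number a weaker inhibitor. For compound 1 the result is a limit of this assay and not a number (the limit of > 5000 nM in this assay, at which 1 of the 3 values shown sits). Compound 4 `CC1CCN(C2CCN(S(=O)(=O)c3cccc(-c4ccccc4)c3)CC2)CC1` has not yet been measured; it differs from compound 1 by phenyl in place of trifluoromethyl on an aromatic carbon. For the measured compounds named here, the only measured step that begins at compound 1 is an at least 290-fold lower number from compound 1 to compound 3 (2.46 log units; beyond the scatter), made by a different change on the same ring. Compound 2, which also carries an aromatic ring on that ring, gives 26 nM in this assay. A large step toward a lower number is therefore expected, an at least 25-fold lower number from compound 1 to compound 4 (1.39 log units; beyond the scatter). Compound 4 is estimated at 200 nM, within a range from 30 nM to 1500 nM.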

Compound 4, half-maximal inhibitory concentration: 2 nM
Compound 4: the middle estimate sits 100-fold (2.00 log units) above what was measured, and the stated range ends above it.
By their numbers in this assay, from the lowest: compound 4; then compounds 3 and 2 (each within the scatter of the next). At a limit, above all of these: compound 1.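

Replacing trifluoromethyl with phenyl on this aromatic carbon, with the rest of the molecule unchanged, gives an at least 2500-fold lower number from compound 1 to compound 4 (3.39 log units; beyond the scatter). For the compounds shown here, the earlier step changed a different carbon of the ring, so this is the first sign that the group at this position can itself have a large effect. For compound 1 the result is a limit of this assay, so the full size of the step cannot be read: the limit of > 5000 nM in this assay, at which 1 of the 4 values shown sits.

The compounds shown leave open whether the gain needs an aromatic ring, which a cyclohexyl group or a longer chain at this carbon could test. They also leave open whether an amine on the added phenyl would keep it.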